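Methoxy for Trifluoromethyl on a Sulfonamide Aryl Ring

This account rests on a few compounds, and the source may have more. Where it says the series, first, only, none or still open, it means among the compounds named here.

Compound 1, `CC1CCN(C2CCN(S(=O)(=O)c3cnc(Cl)s3)CC2)CC1`, in an ADME assay on HCT-116 cells (Homo sapiens) for cytotoxicity, read by CellTiter-Glo, with a stated time of 72 h (on this read-out lower numbers stand for stronger inhibition and higher numbers for weaker inhibition), gives > 10000 nM, a limit of the assay rather than a number.
Compound 2, `COc1ccc(-c2cccc(S(=O)(=O)N3CCC(N4CCC(C)CC4)CC3)c2)cc1`, in this assay gives > 5000 nM, again only a limit.
Compound 3, `CC1CCN(C2CCN(S(=O)(=O)c3cccc(C(F)(F)F)c3)CC2)CC1`, in this assay gives > 5000 nM, also a limit.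

Compound 3 thus stands at the limit of > 5000 nM in this assay, at which 2 of the 3 values shown sit, with no number of its own. Compound 4, `COc1cccc(S(=O)(=O)N2CCC(N3CCC(C)CC3)CC2)c1`, differs from it by methoxy in place of trifluoromethyl on an aromatic carbon. Among the measured compounds shown here, the only measured step touching this part of the shared core, a step that the two limits leave unreadable from compound 2 to compound 3, runs from one limit to another and cannot be read, so it offers no size to lean on. Since every value shown is a limit, no step beyond the scatter is expected in this assay in either direction. Compound 4 is therefore expected to give about 10000 nM, with a range from 5000 nM to 30000 nM, most likely reported again only as a limit. The step that the limit leaves unreadable from compound 3 to compound 4 is expected to be small.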

Compound 4, half-maximal inhibitory concentration: > 5000 nM
Compound 4 ended at the assay's limit; the forecaster's own chance of this, stated with the estimate: 85%; the middle value lies beyond the limit too.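

Among the compounds shown here, compound 1, compound 2, compound 3 and compound 4 all give only limits, so no step among them can be read. The compounds shown leave open what actual number any of them would reach in this assay, and whether methoxy and trifluoromethyl differ at all.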